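Swapping the aryl group on a fused six-ring core

This account rests on a few compounds, and the source may have more. Where it says the series, first, only, none or still open, it means among the compounds named here.

Measured compounds:
- compound 1, `Cc1nc2c3ccccc3ccc2c2nc3c(ccc4ccccc43)c(-c3cccnc3)c12`: 156 ug/mL
- compound 2, `COc1ccc(-c2c3ccc4ccccc4c3nc3c2c(C)nc2c4ccccc4ccc32)cc1`: 176 ug/mL
- compound 3, `Cc1nc2c3ccccc3ccc2c2nc3c(ccc4ccccc43)c(-c3cc(O)nc4ccccc34)c12`: 148 ug/mL

All three share one core and differ only in the aromatic group attached to one carbon of it. In a functional assay, with a stated time of 90 s (on this read-out higher numbers stand for weaker inhibition and lower numbers for stronger inhibition), compound 3 gives the lowest of the three numbers, but the steps of a 1.1-fold lower number from compound 1 to compound 3 (0.02 log units; within the scatter) and a 1.2-fold lower number from compound 2 to compound 3 (0.08 log units; within the scatter) both lie within the scatter, so the three compounds cannot be told apart on these numbers.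

Compound 4, `Cc1nc2c3ccccc3ccc2c2nc3c(ccc4ccccc43)c(-c3ccccc3)c12`, is the next step from compound 3. The change is phenyl in place of 2-hydroxyquinolin-4-yl on an aromatic carbon. The steps already measured at this same position, a 1.1-fold higher number from compound 1 to compound 2 (0.05 log units; within the scatter) and a 1.1-fold lower number from compound 1 to compound 3 (0.02 log units; within the scatter), show that replacing one aromatic group by another here has so far produced no change beyond the scatter. A phenyl group is the smallest of the four groups tried at this position, yet the earlier steps give no reason to expect that size matters for this read-out.

For compound 4 the expected step is a 1.1-fold higher number from compound 3 to compound 4 (0.03 log units; within the scatter) in this assay, which is to say no step beyond the scatter. The estimate for compound 4 is therefore 158 ug/mL, with a likely range from 95 ug/mL to 260 ug/mL.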

Compound 4, half-maximal inhibitory concentration: 188 ug/mL
Compound 4: middle estimate off by 1.2-fold (0.08 log units), on the low side; low and high end bracket the measured number.
By their numbers in this assay, from the lowest: compounds 3, 1, 2 and 4 (each within the scatter of the next).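

Cutting the group at this carbon down to a bare phenyl, with 6 heavy atoms and 0 hydrogen-bond donors in place of the 11 heavy atoms and 1 hydrogen-bond donor of 2-hydroxyquinolin-4-yl, gives a 1.3-fold higher number from compound 3 to compound 4 (0.10 log units; within the scatter) in this assay. The other two comparisons agree, with a 1.1-fold higher number from compound 2 to compound 4 (0.03 log units; within the scatter) for hydrogen in place of methoxy and a 1.2-fold higher number from compound 1 to compound 4 (0.08 log units; within the scatter) for phenyl in place of pyridin-3-yl, so the unsubstituted phenyl ring now joins the other three groups, and none of the four compounds can be told apart from the others at this position. No supporting measurement is available to explain why these quite different aromatic groups give numbers that cannot be separated.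

Every group shown here is an aromatic ring, so it remains open whether an amine, a carboxylic acid or a longer alkyl chain on this carbon would give a step beyond the scatter. Also open, as far as these compounds go, is whether a change to the shared core itself, rather than to this one group, would separate the compounds.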